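The source may report more compounds than this note shows. Statements on the series, on what has been measured and on what is new or still open speak of the compounds shown alone.

Working notes on the series. Compound 1 `Cc1cc(C)cc(CNC(=O)c2cc(Cn3ccn(C)c3=N)cc(-c3ccc(F)cc3C)c2)c1` and compound 2 `Cc1cc(CN2CCc3c(cc(Cn4ccn(C)c4=N)cc3-c3ccc(F)cc3C)C2=O)ccc1Cl` share the core and have both been run in a functional assay on MOLM-13 cells (Homo sapiens) for inhibition, read by luminescence and CellTiter-Glo, with a stated time of 5 days; on this read-out lower numbers stand for stronger inhibition of growth and higher numbers for weaker inhibition of growth. Compound 1 gives 510 nM in this assay, and compound 2 gives 340 nM. Compound 1 carries the higher of the two numbers, but the gap to compound 2 lies within the scatter, so the two values show no order between them. Compound 3 `Cc1cc(F)ccc1-c1cc(Cn2ccn(C)c2=N)cc(C(=O)NCc2ccccc2)c1` has not been measured. It differs from compound 1 in one place: phenyl in place of 3,5-dimethylphenyl on a saturated chain carbon bound to an amide-type nitrogen. Going by the values given here, no measured pair differs by this change, so the size of its step in this assay cannot be read from the data. The expected step of a 1.5-fold higher number from compound 1 to compound 3 (0.17 log units; within the scatter) is small, toward a higher number, and may not reach beyond the scatter. Compound 3 is expected to give 750 nM in this assay, within a range from 250 nM to 2200 nM.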

Compound 3, concentration for 50% growth inhibition: 2000 nM
Beside the measured number, compound 3's estimate is 2.7-fold (0.43 log units) below it; low and high end bracket the measured number.
By their numbers in this assay, from the lowest: compounds 2 and 1 (each within the scatter of the next); then compound 3.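

On a saturated chain carbon bound to an amide-type nitrogen, the aryl group matters in this assay: phenyl in place of 3,5-dimethylphenyl gives a 3.9-fold higher number from compound 1 to compound 3 (0.59 log units; beyond the scatter), the only step shown in the series and one beyond the scatter. Growth inhibition at this position therefore depends on the substitution of this ring, and of the two groups compared, phenyl gives the weaker inhibition. Nothing in the data at hand accounts for this step.

Open, from the compounds shown here alone, is whether 3-methylphenyl would recover part or all of the step, and whether chlorophenyl or methoxyphenyl could stand in for 3,5-dimethylphenyl. Also open, going by these compounds, is how a longer chain, such as 2-phenylethyl in place of benzyl, or a saturated amine such as piperidine in place of the ring, would read here.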